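Switching the aryl group on the ring amine nitrogen

The source may report more compounds than this note shows. Statements on the series, on what has been measured and on what is new or still open speak of the compounds shown alone.

Of the compounds shown here, two have been measured in an ADME assay on CCRF-CEM cells (Homo sapiens) for cytotoxicity, read by MTT assay, with a stated time of 5 days; a lower number here means that less compound is tolerated, a higher number that more compound is tolerated. Compound 1 `COc1cc(Cc2cnc(/N=C3\C(=O)N(CN4CCC(C)CC4)c4ccc(Cl)cc43)nc2N)cc(OC)c1OC` gives 46.3 ug/mL. Among the measured compounds shown here, compound 2 `COc1cc(Cc2cnc(/N=C3\C(=O)N(CN4CCN(c5ccc(Cl)cc5)CC4)c4ccc(Cl)cc43)nc2N)cc(OC)c1OC` gives 40.1 ug/mL, the lower of the two numbers; the gap to compound 1 is within the scatter of this assay, so the two values cannot be told apart, and no single-point step links them.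

Compound 3 `COc1cc(Cc2cnc(/N=C3\C(=O)N(CN4CCN(c5ccccn5)CC4)c4ccc(Cl)cc43)nc2N)cc(OC)c1OC` is not yet measured. It differs from compound 2 by pyridin-2-yl in place of 4-chlorophenyl on an amine nitrogen in a ring, the six-membered non-aromatic ring with two nitrogens.

For the measured compounds named here, nothing among the measured compounds tests this change. The expected step from compound 2 to compound 3 in this assay is a 1.0-fold higher number from compound 2 to compound 3 (0.02 log units; within the scatter), no larger than the scatter in either direction. Compound 3 is thus estimated at 42 ug/mL, with a likely range from 20 ug/mL to 85 ug/mL.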

Compound 3, half-maximal cytotoxic concentration: 29.4 ug/mL
Estimate against measurement, compound 3: 1.4-fold (0.15 log units) above; measured number inside the range.
By their numbers in this assay, from the lowest: compounds 3, 2 and 1 (each within the scatter of the next).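

In this assay the first direct test of this place, pyridin-2-yl in place of 4-chlorophenyl on an amine nitrogen in a ring, gives a 1.4-fold lower number from compound 2 to compound 3 (0.13 log units; within the scatter) and so shows that an aromatic ring with one nitrogen is tolerated as well as the 4-chlorophenyl ring. The wider exchange of 4-(pyridin-2-yl)piperazin-1-yl for 4-methylpiperidin-1-yl gives a 1.6-fold lower number from compound 1 to compound 3 (0.20 log units; within the scatter) and adds a second step that does not separate the compounds. Nothing on hand accounts for these readings.

The compounds shown leave open whether any group at this place can move the number beyond the scatter. A carboxylic acid or an acetyl group in place of the aryl group on the amine nitrogen would test a different kind of substituent from the aromatic rings seen so far.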